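This account rests on a few compounds, and the source may have more. Where it says the series, first, only, none or still open, it means among the compounds named here.

Measured compounds in a functional assay on HeLa cells (Homo sapiens) for antiproliferative activity, read by MTT assay, with a stated time of 48 h; on this read-out higher numbers stand for weaker inhibition and lower numbers for stronger inhibition:
compound 1 `Fc1ccccc1N1CCN(Cn2nc(-c3ccc4c(c3)OCCO4)oc2=S)CC1`: 37300 nM
compound 2 `S=c1oc(-c2ccc3c(c2)OCCO3)nn1CN1CCN(c2cccc(Cl)c2)CC1`: 47200 nM
compound 3 `O=[N+]([O-])c1ccc(N2CCN(Cn3nc(-c4ccc5c(c4)OCCO5)oc3=S)CC2)cc1`: 31700 nM

Of the three numbers, that of compound 2 is the largest, but the steps of a 1.3-fold higher number from compound 1 to compound 2 (0.10 log units; within the scatter) and a 1.5-fold lower number from compound 2 to compound 3 (0.17 log units; within the scatter) both lie within the scatter, so the three compounds are not separated on this read-out.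

Compound 4 `S=c1oc(-c2ccc3c(c2)OCCO3)nn1CN1CCN(c2ccccn2)CC1` differs from compound 2 by pyridin-2-yl in place of 3-chlorophenyl on an amine nitrogen in a ring. Within the data shown here, the steps that bear on this change are the other swaps of the aryl on the same ring nitrogen: a 1.3-fold higher number from compound 1 to compound 2 (0.10 log units; within the scatter), a 1.5-fold lower number from compound 2 to compound 3 (0.17 log units; within the scatter) and a 1.2-fold lower number from compound 1 to compound 3 (0.07 log units; within the scatter), all within the scatter. Among the measured compounds shown here, none of the measured compounds carries pyridin-2-yl at this place, so the expectation rests on those three steps only: no step beyond the scatter is expected in this assay, that is a 1.2-fold lower number from compound 2 to compound 4 (0.07 log units; within the scatter). Compound 4 is accordingly estimated at 40000 nM, with a range from 15000 nM to 100000 nM.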

Compound 4, half-maximal inhibitory concentration: 25100 nM
Estimate against measurement, compound 4: 1.6-fold (0.20 log units) above; measured number inside the range.
By their numbers in this assay, from the lowest: compounds 4, 3, 1 and 2 (each within the scatter of the next).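

In this assay, among these compounds, pyridin-2-yl is the only group on this amine nitrogen with a hetero atom in its aromatic ring and a hydrogen-bond acceptor, yet the steps of a 1.9-fold lower number from compound 2 to compound 4 (0.27 log units; within the scatter) and a 1.3-fold lower number from compound 3 to compound 4 (0.10 log units; within the scatter) and a 1.5-fold lower number from compound 1 to compound 4 (0.17 log units; within the scatter) all stay within the scatter. Replacing the carbon-only aromatic ring with this ring therefore does not separate compound 4 from the other three compounds. No measured finding accompanies these numbers to explain them.

Still open, going by these compounds, is whether a non-aromatic group on this nitrogen, such as a benzyl group, an aliphatic chain bearing an amine or a carboxylic acid, would move the number beyond the scatter. Also open, on these data alone, is whether changes elsewhere on the shared core would do so.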